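The source may report more compounds than this note shows. Statements on the series, on what has been measured and on what is new or still open speak of the compounds shown alone.

Compound 1 `CNC(=O)C(CC1CCCCC1)Nc1nc2cc(C)ccc2o1` (72 nM)
Compound 2 `Cc1ccc2oc(NC(CC3CCCCC3)c3ccccn3)nc2c1` (4 nM)
Compound 3 `Cc1ccc2oc(N[C@H](CC3CCCCC3)c3ccccn3)nc2c1` (40 nM)

All three were tested in a functional assay for inhibition, with Homo sapiens as the target (a lower number here means a stronger inhibitor, a higher number a weaker inhibitor), and compound 2 gives the lowest number of the three (4 nM), which makes it the strongest inhibitor among them. Compound 4 `Cc1ccc2oc(NC(CC3CCCCC3)c3ccncc3)nc2c1` has not yet been measured. It has pyridin-4-yl in place of pyridin-2-yl on a saturated chain carbon bound to a nitrogen on an aromatic ring and a saturated chain carbon.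

Within the data shown here, two measured steps bear on this change. Among the measured compounds shown here, the first swaps the group on that same carbon, methylcarbamoyl for pyridin-2-yl, and it is large (an 18-fold lower number from compound 1 to compound 2 (1.26 log units; beyond the scatter)). The second involves that carbon too and is also beyond the scatter (a 10-fold higher number from compound 2 to compound 3 (1.00 log units; beyond the scatter)), with the pair separated only by how they are drawn (the fact that one of compounds 2 and 3 is drawn with a defined configuration and the other without, at the place where they differ). Both show that changes at this carbon can shift the number considerably. For the measured compounds named here, no measured compound carries pyridin-4-yl, so the size of this swap remains open. Compound 2 already sits lowest (4 nM), so a modest rise is the more likely outcome. The expected step is modest and towards a higher number (a 3.8-fold higher number from compound 2 to compound 4 (0.57 log units; beyond the scatter)). Compound 4 is expected at 15 nM (estimated range 3 nM to 70 nM).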

Compound 4, half-maximal inhibitory concentration: 190 nM
The estimate for compound 4 lay 13-fold (1.10 log units) below the measured number, and the stated range ends below it.
By their numbers in this assay, from the lowest: compound 2; then compounds 3 and 1 (each within the scatter of the next); then compound 4.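

In this assay, the two groups that swap here have identical counts of atoms, rings, donors and acceptors, and the two compounds have the same atoms, joined differently, yet the step is large: a 48-fold higher number from compound 2 to compound 4 (1.68 log units; beyond the scatter). So the earlier gain from placing a pyridine ring on this saturated chain carbon does not belong to any pyridine ring, but depends on which pyridinyl group is attached, and pyridin-2-yl is the better of the two shown. The swap from the amide group also reverses direction with the new ring, since the step with pyridin-4-yl runs the opposite way to the one with pyridin-2-yl, a 2.6-fold higher number from compound 1 to compound 4 (0.42 log units; beyond the scatter), and nothing recorded for these compounds explains why the two pyridinyl groups differ.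

The compounds shown leave open where pyridin-3-yl or a plain phenyl ring, which has no ring nitrogen, would fall relative to these two groups. From the compounds shown here alone, compound 4 is also drawn without a configuration, so how its separate mirror-image forms would compare remains unknown.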